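Swapping the ring on the ether oxygen for a methyl

A few compounds are considered here, and "the series" means these few. Any claim that something is new, unique, unknown or untested is made for them only; others in the source may bear on it.

Of the compounds shown here, three sharing one core have been measured so far. Compound 1 `NC(=O)c1ccc(-c2cccnc2)cc1OC1CCC1` gives 1900 nM in an assay on cells for inhibition of MAP kinase-interacting serine/threonine-protein kinase 1 (Homo sapiens), read by mobility shift assay, with stated times of 10 min and 60 min, in the presence of a further agent that is not named here (a lower number here means a stronger inhibitor, a higher number a weaker inhibitor), compound 2 `CCOc1cc(-c2cccnc2)ccc1C(N)=O` gives 2200 nM, and compound 3 `NC(=O)c1ccc(-c2cccnc2)cc1OC1CCNCC1` gives 1100 nM. On these numbers compound 3 stands at the lower end, but the steps to it, a 1.7-fold lower number from compound 1 to compound 3 (0.24 log units; within the scatter) and a 2.0-fold lower number from compound 2 to compound 3 (0.30 log units; within the scatter), are within the scatter, as is the step of a 1.2-fold higher number from compound 1 to compound 2 (0.06 log units; within the scatter). Nothing measured here separates the three groups on the ether oxygen beyond noise.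

Compound 4 `COc1cc(-c2cccnc2)ccc1C(N)=O` is not yet measured. It differs from compound 3 in one place: methyl in place of piperidin-4-yl on an oxygen on an aromatic ring. Within the data shown here, the step that bears most closely on it is the one from compound 2 to compound 3, since ethyl and methyl are both short chains on that oxygen, and that step, a 2.0-fold lower number from compound 2 to compound 3 (0.30 log units; within the scatter), was within the scatter. The step of a 1.7-fold lower number from compound 1 to compound 3 (0.24 log units; within the scatter) points the same way in size. Reversing such a change is therefore expected to move the number little, if at all, in this assay.

Compound 4 is expected to give about 2300 nM, within a range from 1200 nM to 4500 nM, which means an expected step of a 2.1-fold higher number from compound 3 to compound 4 (0.32 log units; beyond the scatter).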

Compound 4, half-maximal inhibitory concentration: 2800 nM
Compound 4: middle estimate off by 1.2-fold (0.09 log units), on the low side; the range from low to high includes it.
By their numbers in this assay, from the lowest: compounds 3, 1, 2 and 4 (each within the scatter of the next, the first and the last beyond it).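

In this assay, among these compounds, the step of a 2.5-fold higher number from compound 3 to compound 4 (0.41 log units; beyond the scatter) is the first change on this ether oxygen to pass beyond the scatter, so piperidin-4-yl and methyl can be told apart here, though the gap is modest. The smaller changes do not separate: a 1.3-fold higher number from compound 2 to compound 4 (0.10 log units; within the scatter) and a 1.5-fold higher number from compound 1 to compound 4 (0.17 log units; within the scatter) both stay within the scatter, which leaves methyl, ethyl and cyclobutyl on this oxygen indistinguishable, and compound 3 is likewise not separated from compound 1 or compound 2, so the one clear gap holds only against methyl. No measurement at hand explains that gap.

Still open, on these data alone, is whether the nitrogen of the piperidin-4-yl ring matters at all, since compound 3 stays within the scatter of compound 1, whose cyclobutyl ring has no nitrogen. An aminoethyl chain on the same oxygen would show how an amine behaves without the ring, and a carboxylic acid carried on a short chain there would show how a quite different end group compares.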